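This account rests on a few compounds, and the source may have more. Where it says the series, first, only, none or still open, it means among the compounds named here.

Measured so far in an assay on isolated protein for inhibition of histone deacetylase 4 (Homo sapiens), with a stated time of 1 h; a lower number here means a stronger inhibitor, a higher number a weaker inhibitor:
- compound 1, `O=C(COc1ccc2cc(/C=C3/SC(=O)NC3=O)ccc2c1)Nc1ccc(Br)cc1`, gives 2900 nM
- compound 2, `O=C(COc1ccc2cc(/C=C3/SC(=O)NC3=O)ccc2c1)Nc1c(F)cc(F)cc1Br`, gives 1100 nM
- compound 3, `O=C(COc1ccc2cc(/C=C3/SC(=O)NC3=O)ccc2c1)Nc1ccc(Br)c(Br)c1`, gives 4900 nM

Among these three numbers compound 1 stands second highest. Its nearest neighbour is compound 3, reached by a 1.7-fold higher number from compound 1 to compound 3 (0.23 log units; within the scatter), a step that stays within the scatter. Compound 2 lies furthest away, by a 2.6-fold lower number from compound 1 to compound 2 (0.42 log units; beyond the scatter), and the step of a 4.5-fold higher number from compound 2 to compound 3 (0.65 log units; beyond the scatter) connects the two outer compounds.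

Compound 4, `O=C(COc1ccc2cc(/C=C3/SC(=O)NC3=O)ccc2c1)Nc1ccc(Cl)c(Cl)c1`, has not yet been measured in this assay. It differs from compound 1 in one place: 3,4-dichlorophenyl in place of 4-bromophenyl on an amide-type nitrogen

For the measured compounds named here, the measured step that bears most on this change is the one from compound 1 to compound 3, in which bromo in place of hydrogen on an aromatic carbon also turned a single-halogen ring into a doubly halogenated one; that step, a 1.7-fold higher number from compound 1 to compound 3 (0.23 log units; within the scatter), stayed within the scatter. No measured pair exchanges bromine for chlorine, so that part of the change is unsupported by the numbers shown. The expectation is therefore a step of about a 1.3-fold higher number from compound 1 to compound 4 (0.12 log units; within the scatter), leaning toward a higher number but not clearly beyond the scatter. Compound 4 is estimated at 3800 nM, with a range from 1500 nM to 9500 nM.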

Compound 4, half-maximal inhibitory concentration: 5500 nM
For compound 4 the middle estimate is 1.4-fold (0.16 log units) below the measured one; low and high end bracket the measured number.
By their numbers in this assay, from the lowest: compound 2; then compounds 1, 3 and 4 (each within the scatter of the next).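

For the compounds shown here, the exchange of 3,4-dibromophenyl for 3,4-dichlorophenyl gives the first direct look at bromine against chlorine on this ring attached to the amide-type nitrogen, and in this assay the step (a 1.1-fold higher number from compound 3 to compound 4 (0.05 log units; within the scatter)) does not separate the two halogens. The exchange of 4-bromophenyl for 3,4-dichlorophenyl (a 1.9-fold higher number from compound 1 to compound 4 (0.28 log units; within the scatter)) also stays within the scatter, so compounds 1, 3 and 4 cannot be ranked against one another, even though their rings carry different halogens in different numbers. Only the 2-bromo-4,6-difluorophenyl ring stands apart from this group, and the new compound confirms that separation (a 5.0-fold higher number from compound 2 to compound 4 (0.70 log units; beyond the scatter)), though no measurement is available to explain it.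

These compounds leave open which part of the 2-bromo-4,6-difluorophenyl ring carries its difference, since that ring differs from the others in several features at once. They also leave open how the number would respond if the halogens on this ring gave way to a different kind of group, such as an amine, a carboxylic acid or a methoxy group.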